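Swapping the ring on the ketone: what compound 3 may tolerate

The compounds below may be only part of what the source reports. "The series", "measured", "known", "first", "only" and "open" are said of these compounds alone.

Compound 2 `COC(=O)c1cc(-c2cccc(NC(=O)c3ccc(/C=C/C(=O)c4cccc(C(F)(F)F)c4)cc3)c2)on1` is one of two measured members of a small series built on a shared core. In an ADME assay on Vero cells (Chlorocebus sabaeus) for cytotoxicity, read by MTT assay, with a stated time of 72 h (a higher number here means that more compound is tolerated, a lower number that less compound is tolerated), compound 2 gives > 20 ug/mL, which is a limit of the assay rather than a number. Compound 1 `COC(=O)c1cc(-c2cccc(NC(=O)c3ccc(/C=C/C(=O)c4cc(F)ccc4F)cc3)c2)on1` differs from it only in the ring on the carbonyl carbon. In this assay compound 1 gives > 40 ug/mL, again a limit. Within the data shown here, the step that the two limits leave unreadable from compound 1 to compound 2 is the only measured step that bears on the change at hand, and its size cannot be read. Compound 3 `COC(=O)c1cc(-c2cccc(NC(=O)c3ccc(/C=C/C(=O)c4ccccc4Br)cc3)c2)on1` is not yet measured; it differs from compound 2 by 2-bromophenyl in place of 3-(trifluoromethyl)phenyl on a carbonyl carbon. Because compound 1 sits at the limit of > 40 ug/mL in this assay, at which 1 of the 2 values shown sits, and compound 2 at the limit of > 20 ug/mL in this assay, at which 1 of the 2 values shown sits, no step beyond the scatter in this assay can be foreseen in either direction. Compound 3 is therefore expected to give 30 ug/mL in this assay, within 15 ug/mL to 60 ug/mL. The estimated step that the limit leaves unreadable from compound 2 to compound 3 is none beyond the scatter.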

Compound 3, half-maximal cytotoxic concentration: > 40 ug/mL
Compound 3: a limit, no number; the forecaster's own chance of this, stated with the estimate: 70%; middle value at least 1.3-fold (0.12 log units) away from the limit.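

Among these compounds, compound 1, compound 2 and compound 3 all give limits rather than numbers in this assay, and no step among them can be read. The compounds shown leave open how much of each compound the cells tolerate, and whether swapping the ring on the carbonyl carbon changes that at all.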